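The compounds below may be only part of what the source reports. "The series", "measured", "known", "first", "only" and "open" are said of these compounds alone.

Measured in a functional assay on HCT-8 cells (Homo sapiens) for antiproliferative activity, read by sulforhodamine B assay, with a stated time of 3 days; on this read-out higher numbers stand for an effect only at larger amounts of compound and lower numbers for an effect already at smaller amounts:
- compound 1 `CCCC1(CC=C(C)C)C(=O)C(C(=O)/C=C/c2ccccc2)=C(O)C(CCC)(CCC)C1=O` gives 6.7 uM
- compound 2 `CCCC1=C(OCC(C)C)C(CCC)(CCC)C(=O)/C(=C(O)\C=C\c2ccccc2)C1=O` gives 8 uM
- compound 3 `COC1=C(CC=C(C)C)C(=O)/C(=C(O)/C=C/c2ccccc2)C(=O)C1(CC=C(C)C)CC=C(C)C` gives 13.7 uM

Compound 2 stands second highest of the three numbers. Its nearest neighbour is compound 1, whose value lies within the scatter of that of compound 2; its furthest is compound 3, whose value also lies within the scatter. The three numbers therefore sit together, and no ranking among them can be read from them.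

Compound 4 `CCCC1=C(OC)C(CCC)(CCC)C(=O)/C(=C(O)\C=C\c2ccccc2)C1=O` has not yet been measured in this assay. It differs from compound 2 in one place: hydrogen in place of isopropyl on a saturated chain carbon bound to an oxygen on an unsaturated carbon. Going by the values given here, no pair of measured compounds isolates this change. Compound 3 also carries a methoxy, but it differs from compound 2 in further places, so its value reflects the whole of compound 3 and not this change alone.

For compound 4 in this assay the expected step is a 1.1-fold higher number from compound 2 to compound 4 (0.05 log units; within the scatter), that is, none beyond the scatter. Compound 4 is estimated at 9 uM, with a range from 4 uM to 20 uM.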

Compound 4, concentration for half-maximal effect: 3.5 uM
Compound 4: the middle estimate sits 2.6-fold (0.41 log units) above what was measured; the whole stated range lies above it.
By their numbers in this assay, from the lowest: compounds 4, 1, 2 and 3 (each within the scatter of the next, the first and the last beyond it).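

In this assay, going by these compounds alone, going from isobutoxy to methoxy on the shared core gives a 2.3-fold lower number from compound 2 to compound 4 (0.36 log units; beyond the scatter), the first step that lies beyond the scatter. The three earlier values sat together and gave no sign that any one place matters, whereas this pair shows that the chain on this oxygen can move the read-out, with the methyl-bearing compound 4 acting at smaller amounts. The direction rests on this single pair and holds only for isobutyl against methyl at this place.

From the compounds shown here alone, whether the trend runs smoothly through ethoxy, and what a free hydroxyl or a longer chain ending in an amine or a carboxylic acid would do on this oxygen, remains open. Nothing measured here gives a reason for the step.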